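Swapping the Heteroaryl Ring Back to a Halothiophene

The source may hold more compounds than are shown below. What is called first, only, known or untested is meant among the compounds shown, and "the series" means these compounds.

Two compounds share a core in which a sulfur bearing an oxygen links a diphenylmethyl group to a saturated chain carbon carrying an aromatic ring. Compound 1 `[O-][S+](Cc1ccc(Cl)s1)C(c1ccccc1)c1ccccc1` carries 5-chlorothiophen-2-yl there, and in an assay on HEK293 cells for inhibition of sodium-dependent dopamine transporter (Homo sapiens), read by scintillation counting, with stated times of 5 min and 1 min (a lower number here means a stronger inhibitor, a higher number a weaker inhibitor), compound 1 gives 12800 nM. Compound 2 `[O-][S+](Cc1cc(C2CC2)on1)C(c1ccccc1)c1ccccc1` carries 5-cyclopropyl-1,2-oxazol-3-yl instead, and in this assay compound 2 gives 38600 nM. Within the data shown here, the single measured step, a 3.0-fold higher number from compound 1 to compound 2 (0.48 log units; beyond the scatter), thus weakened inhibition by a modest amount. Among the two numbers in hand, compound 2 stands at the weaker end, its only neighbour being compound 1.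

Compound 3 `[O-][S+](Cc1csc(Br)c1)C(c1ccccc1)c1ccccc1` is not yet measured; it differs from compound 2 in one place: 5-bromothiophen-3-yl in place of 5-cyclopropyl-1,2-oxazol-3-yl on a saturated chain carbon bound to a sulfur. Among the measured compounds shown here, this change runs against the direction of the only measured step, restoring a thiophene carrying a halogen as in compound 1, though the exact group differs. For the measured compounds named here, that step from compound 1 to compound 2 is the only evidence bearing on it. Compound 3 is therefore expected to recover much of what compound 2 lost, a step of about a 2.6-fold lower number from compound 2 to compound 3 (0.41 log units; beyond the scatter) in this assay. Compound 3 is estimated to give 15000 nM, with a range from 6000 nM to 40000 nM.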

Compound 3, half-maximal inhibitory concentration: 16600 nM
Beside the measured number, compound 3's estimate is 1.1-fold (0.04 log units) below it; measured number inside the range.
By their numbers in this assay, from the lowest: compounds 1 and 3 (each within the scatter of the next); then compound 2.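

The thiophene carrying a halogen brings the number back down, with a 2.3-fold lower number from compound 2 to compound 3 (0.37 log units; beyond the scatter) in this assay, so the loss seen with 5-cyclopropyl-1,2-oxazol-3-yl on this saturated chain carbon bound to a sulfur is reversible. Among these compounds, the new group is not the same as the one in the first compound, yet a 1.3-fold higher number from compound 1 to compound 3 (0.11 log units; within the scatter), so 5-bromothiophen-3-yl and 5-chlorothiophen-2-yl cannot be told apart here, even though they differ in both the halogen and the numbering in their names. Among these three compounds, then, the two halothiophenes read alike and the cyclopropyl-bearing ring stands apart, but nothing measured here explains why this is so.

Each swap changes the ring and its substituent together, so these compounds leave open whether the thiophene, the halogen or the loss of the cyclopropyl group accounts for the difference. How a thiophene with a methyl group in place of the halogen, or one carrying an amine, would read in this assay also remains an open question.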